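The source may report more compounds than this note shows. Statements on the series, on what has been measured and on what is new or still open speak of the compounds shown alone.

Three compounds of the series have been run in a functional assay on 786-0 cells (Homo sapiens) for inhibition, read by sulforhodamine B assay, with a stated time of 48 h; on this read-out lower numbers stand for stronger inhibition of growth and higher numbers for weaker inhibition of growth. Compound 1 `O=C1C=CCC(/C=C/c2ccc(C(F)(F)F)cc2)O1` gives 44.5 uM, compound 2 `COc1ccc(/C=C/C2CC=CC(=O)O2)cc1` gives 21.6 uM, and compound 3 `COc1ccc(/C=C/C2CC=CC(=O)O2)c(OC)c1` gives 4.1 uM. On these numbers compound 2 stands second highest of the three: compound 1 is its nearest neighbour, at a 2.1-fold lower number from compound 1 to compound 2 (0.31 log units; beyond the scatter), and compound 3 is the furthest, at a 5.3-fold lower number from compound 2 to compound 3 (0.72 log units; beyond the scatter).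

Compound 4 `COc1ccc(/C=C/C2CC=CC(=O)O2)cc1OC` has not yet been run in this assay. It differs from compound 2 in one place: methoxy in place of hydrogen on an aromatic carbon. Among the compounds with values here, the only measured step of the same kind is the one from compound 2 to compound 3, where the methoxy entered at another place on the same aromatic ring and gave a 5.3-fold lower number from compound 2 to compound 3 (0.72 log units; beyond the scatter); the step from compound 1 to compound 2 concerns a different exchange and bears only indirectly. One measured step is a thin basis, and the entering group sits at a new place, so a lower number than compound 2 is expected but with less confidence in its size. Compound 4 is estimated to give 8 uM, with a range from 3 uM to 25 uM. That estimate corresponds to an expected step of a 2.7-fold lower number from compound 2 to compound 4 (0.43 log units; beyond the scatter) in this assay.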

Compound 4, concentration for growth inhibition (reported as GI): 10.9 uM
Estimate against measurement, compound 4: 1.4-fold (0.13 log units) below; the measured number falls inside the stated range.
By their numbers in this assay, from the lowest: compound 3; then compounds 4 and 2 (each within the scatter of the next); then compound 1.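

Notes on the position ortho to a methoxy group and meta to a group of 9 heavy atoms: in this assay, methoxy in place of hydrogen here gives a 2.0-fold lower number from compound 2 to compound 4 (0.30 log units; within the scatter), so compound 4 cannot be told apart from compound 2. The same exchange elsewhere on the ring gave a 5.3-fold lower number from compound 2 to compound 3 (0.72 log units; beyond the scatter), so across these two steps a second methoxy does not carry a step beyond the scatter at every place on the ring; the outcome depends on where it enters, with compound 3 at 4.1 uM and compound 4 at 10.9 uM. No measurement at hand accounts for this dependence on place.

The compounds shown leave open whether this place responds to any exchange at all, since methoxy is the only group seen here, and a hydroxy group, a chlorine atom, an amine or a longer ethoxy chain could read differently. They also leave open whether a methoxy at this place would behave the same with the existing methoxy replaced by hydrogen or by trifluoromethyl.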